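From a five-membered aromatic ring to 3-methylphenyl

A few compounds are considered here, and "the series" means these few. Any claim that something is new, unique, unknown or untested is made for them only; others in the source may bear on it.

In a functional assay on HOS-TE85 cells (Homo sapiens) for inhibition, read by CCK-8 assay, with a stated time of 72 h (a lower number here means a stronger inhibitor, a higher number a weaker inhibitor), compound 3 (`CC(C)(C)c1conc1N1C(=O)CSC1c1cccc(C(=O)NCCCCc2ccccc2)c1`) gives > 1000 nM, which is a limit and not a number. Compound 3 therefore stands at the limit of > 1000 nM in this assay, at which 1 of the 3 values shown sits.

Compound 4 (`Cc1cccc(N2C(=O)CSC2c2cccc(C(=O)NCCCCc3ccccc3)c2)c1`) has not yet been measured. It differs from compound 3 on an amide-type nitrogen in a ring: a group of 7 heavy atoms (7 carbon; one six-membered aromatic ring of carbon only) in place of a group of 9 heavy atoms (7 carbon, 1 nitrogen, 1 oxygen; one five-membered aromatic ring with 2 hetero atoms), on an amide-type nitrogen in a ring. The entering group is 3-methylphenyl.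

For the measured compounds named here, one measured step bears on this change at the same site, and it runs the opposite way: an at least 3.3-fold higher number from compound 1 to compound 3 (0.52 log units; beyond the scatter). Going by the values given here, compound 1 (`COc1ccc(C)cc1N1C(=O)CSC1c1cccc(C(=O)NCCCCc2ccccc2)c1`) gives 300 nM and also carries a six-membered aromatic ring of carbon only at that site, although its group is not the same as the one in compound 4. Among the compounds with values here, compound 2 (`COc1ccccc1N1C(=O)CSC1c1cc(C(=O)NCCCCc2ccccc2)cc(C2CC2)c1`) gives 23.5 nM, but no single-place step links it to the other compounds, so it sets no expectation here.

With compound 1 at 300 nM as the closest reference, a step of at least modest size towards a lower number is expected in this assay. The expected step is an at least 2.2-fold lower number from compound 3 to compound 4 (0.34 log units; beyond the scatter), and its size remains loose since it starts from a limit. For compound 4 the estimated value is 450 nM, with an expected range of 150 nM to 1200 nM.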

Compound 4, half-maximal inhibitory concentration: 93.2 nM
The estimate for compound 4 lay 4.8-fold (0.68 log units) above the measured number; measured number outside the range, below it.
By their numbers in this assay, from the lowest: compound 2; then compound 4; then compound 1. At a limit, above all of these: compound 3.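

In this assay, the change on the amide-type nitrogen in a ring gives an at least 10-fold lower number from compound 3 to compound 4 (1.03 log units; beyond the scatter), a large step that shows 3-methylphenyl is far better tolerated at this place than the five-membered aromatic ring with 2 hetero atoms of compound 3. From the compounds shown here alone, compound 3 stands at a limit and not a number, so the true size of this step stays open: the limit of > 1000 nM in this assay, at which 1 of the 4 values shown sits. The second step, a 3.2-fold lower number from compound 1 to compound 4 (0.51 log units; beyond the scatter), goes beyond the scatter and adds what compound 1 alone could not show: with hydrogen in place of methoxy on an aromatic carbon, the number falls, so within this pair the methoxy is not needed for activity.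

For the compounds shown here, compound 2 gives 23.5 nM and carries a methoxy group, but no single-place step links it to compound 4, so the effect of removing methoxy cannot be carried over to that compound. The compounds shown also leave open how an amine, a hydroxyl group or a fluorine in place of the methyl group of compound 4 would read in this assay.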